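Working notes on a gastric inhibition series

The compounds below may be only part of what the source reports. "The series", "measured", "known", "first", "only" and "open" are said of these compounds alone.

Measured so far:
compound 1, `COc1ccc(-c2oc3ccc(C(=O)O)cc3c(=O)c2O)cc1`, 24%
compound 2, `COc1c(-c2ccc(C)cc2)oc2ccc(C(=O)O)cc2c1=O`, 4%

In a functional assay on the whole organism (stomach) for inhibition, with Rattus norvegicus as the target, at a dose of 80 mg/kg (a higher number here means more inhibition at the dose given (going by the name of the read-out), a lower number less inhibition), compound 1 gives 24%, while compound 2 gives 4%. Compound 2 thus stands lowest of the two numbers, and its nearest neighbour is compound 1, which lies higher by a gap beyond the scatter. For the measured compounds named here, no single-change step between these two compounds is known, so only the two values themselves can be compared.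

Compound 3, `COc1ccc(-c2oc3ccc(C(=O)O)cc3c(=O)c2OC)cc1`, has not yet been measured in this assay. It differs from compound 2 as follows: methoxy in place of methyl on an aromatic carbon.

Nothing measured here isolates this change, so the expected step is modest: a small rise, possibly no more than the scatter, is expected for a number 8 percentage points higher from compound 2 to compound 3 (within the scatter). Compound 3 is estimated at 12%, with a range from 0% to 30%.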

Compound 3, a percentage reported as inhibition, in the whole organism at one dose (the size of the read-out at that dose, not a potency): 22%
Compound 3: middle estimate off by 10 percentage points, on the low side; low and high end bracket the measured number.
By their numbers in this assay, from the lowest: compound 2; then compounds 3 and 1 (each within the scatter of the next).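

In this assay, for the compounds shown here, the change from 4-methylphenyl to 4-methoxyphenyl is the first single change that can be read, and it gives a number 18 percentage points higher from compound 2 to compound 3 (beyond the scatter). The group para to a large group therefore registers in this read-out, at least for this pair. On the oxygen on the core, methyl in place of hydrogen gives a number 2 percentage points lower from compound 1 to compound 3 (within the scatter), so hydrogen and methyl at that oxygen are not told apart here, and nothing available bears on the reason for either step.

Open, going by these compounds, is whether an amine, a chlorine or a longer chain such as ethoxy at the para place would read like methoxy or like methyl. Also open, on these data alone, is whether the 4-methoxyphenyl step holds with hydrogen rather than methyl on the core oxygen.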